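A few compounds are considered here, and "the series" means these few. Any claim that something is new, unique, unknown or untested is made for them only; others in the source may bear on it.

The measured compounds and their values in a functional assay on MCF7 cells (Homo sapiens) for antiproliferative activity, read by MTT assay, with a stated time of 48 h; on this read-out lower numbers stand for stronger inhibition and higher numbers for weaker inhibition:

Compound 1, `N#CC1=C(N)Oc2c(N)cc3nc4ccccc4nc3c2C12C(=O)N(Cc1cnnn1-c1cccc(Br)c1)c1ccccc12`, gives > 50000 nM, which is a limit of the assay and not a number.
Compound 2, `N#CC1=C(N)Oc2c(N)cc3nc4ccccc4nc3c2C12C(=O)N(Cc1cnnn1-c1cccc(C(F)(F)F)c1)c1ccccc12`, gives 31600 nM.
Compound 3, `CCc1cccc(CC)c1-n1nncc1CN1C(=O)C2(C(C#N)=C(N)Oc3c(N)cc4nc5ccccc5nc4c32)c2ccccc21`, gives > 50000 nM, again a limit of the assay and not a number.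

Compound 3 thus stands only at a limit, and it shares that limit with one other compound (the limit of > 50000 nM in this assay, at which 2 of the 3 values shown sit); compound 2 is the only one of the three with a number. The next compound, compound 4, `N#CC1=C(N)Oc2c(N)cc3nc4ccccc4nc3c2C12C(=O)N(Cc1cnnn1-c1ccc(F)c(Cl)c1)c1ccccc12`, differs from compound 3 by 3-chloro-4-fluorophenyl in place of 2,6-diethylphenyl on an aromatic nitrogen. Among the measured compounds shown here, two measured steps touch this position. One is an at least 1.5-fold higher number from compound 2 to compound 3 (0.19 log units; that floor lies within the scatter), which runs from a number up to the limit. The other is a step that the two limits leave unreadable from compound 1 to compound 3. Compound 4, like compound 1 and compound 2, carries a halogen-bearing phenyl rather than the 2,6-diethylphenyl, so the step from compound 3 is expected to run back the way the step from compound 2 to compound 3 went, giving an at least 1.4-fold lower number from compound 3 to compound 4 (0.15 log units; that floor lies within the scatter) in this assay, with a fair chance that only a limit is reported. Compound 4 is estimated at 35000 nM, within a range from 12000 nM to 60000 nM.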

Compound 4, half-maximal inhibitory concentration: 17800 nM
Compound 4: middle estimate off by 2.0-fold (0.29 log units), on the high side, and the stated range covers the measured number.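

In this assay, among the compounds shown here, putting 3-chloro-4-fluorophenyl on this aromatic nitrogen gives an at least 2.8-fold lower number from compound 3 to compound 4 (0.44 log units; beyond the scatter) when it replaces 2,6-diethylphenyl and an at least 2.8-fold lower number from compound 1 to compound 4 (0.44 log units; beyond the scatter) when it replaces 3-bromophenyl, so the group at this position can move the result beyond the usual scatter, which no earlier step could show. Between the two compounds with real numbers there is a 1.8-fold lower number from compound 2 to compound 4 (0.25 log units; within the scatter) and no more, so 3-chloro-4-fluorophenyl and 3-(trifluoromethyl)phenyl cannot be told apart here. A halogen on the phenyl ring does not by itself guarantee a number, since compound 1, which carries bromo, gives > 50000 nM as a limit and not a number.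

As far as these compounds go, whether an unsubstituted phenyl, or a phenyl bearing an amine or a carboxylic acid, would go further in either direction stays open, and all the numbers so far come from a single cell line. The step between the two compounds at the limit cannot be read, and neither compound can be placed against the others more exactly: the limit of > 50000 nM in this assay, at which 2 of the 4 values shown sit.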